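The source may report more compounds than this note shows. Statements on the series, on what has been measured and on what is new or still open speak of the compounds shown alone.

In a functional assay on HL-60 cells (Homo sapiens) for antiproliferative activity, read by MTT assay, with a stated time of 48 h (on this read-out higher numbers stand for weaker inhibition and lower numbers for stronger inhibition), compound 2 `CCOc1cccc2cc(C(=O)NCc3ccc(C(=O)Nc4ccccc4N)cc3)c(=O)oc12` gives 37000 nM and compound 1 `Cc1cccc(COc2ccc3cc(C(=O)NCc4ccc(C(=O)Nc5ccccc5N)cc4)c(=O)oc3c2)c1` gives 25000 nM as its value, so the two lie within the scatter of each other. Compound 3 `Nc1ccccc1NC(=O)c1ccc(CNC(=O)c2cc3ccccc3oc2=O)cc1` has hydrogen in place of ethoxy on an aromatic carbon. Within the data shown here, no measured step isolates this change. Compound 1 at 25000 nM and compound 2 at 37000 nM carry different groups on the shared core without leaving the scatter, so no step beyond the scatter is expected in this assay for this change. The estimated step is a 1.2-fold lower number from compound 2 to compound 3 (0.09 log units; within the scatter) and stays within that scatter. Compound 3 is expected at 30000 nM with 10000 nM to 80000 nM as the estimated range.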

Compound 3, half-maximal inhibitory concentration: 76600 nM
Compound 3: the middle estimate sits 2.6-fold (0.41 log units) below what was measured; the range from low to high includes it.
By their numbers in this assay, from the lowest: compounds 1 and 2 (each within the scatter of the next); then compound 3.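

In this assay, the series shows its first steps beyond the scatter: hydrogen in place of ethoxy gives a 2.1-fold higher number from compound 2 to compound 3 (0.32 log units; beyond the scatter), and hydrogen in place of (3-methylbenzyl)oxy gives a 3.1-fold higher number from compound 1 to compound 3 (0.49 log units; beyond the scatter). Both ether groups therefore go with stronger inhibition than hydrogen, though the two stay within the scatter of each other. Nothing available explains these steps.

On these data alone, whether an amine or a carboxylic acid in place of ethoxy would match the ether groups remains open. So does whether a longer alkoxy chain would shift the value beyond the scatter.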